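A few compounds are considered here, and "the series" means these few. Any claim that something is new, unique, unknown or untested is made for them only; others in the source may bear on it.

Of the compounds shown here, three of one shared core have been measured in a functional assay on MCF7 cells (Homo sapiens) for inhibition, read by resazurin assay, with a stated time of 72 h; a lower number here means a stronger inhibitor, a higher number a weaker inhibitor. Compound 1 `CCOc1ccc(C2C(Oc3ccccc3)C(=O)N2c2cc(OC)c(OC)c(OC)c2)cc1` gives 69 nM. Compound 2 `CCSc1ccc(C2CC(=O)N2c2cc(OC)c(OC)c(OC)c2)cc1` gives 141 nM, which is the highest of the three numbers; it lies within the scatter of compound 3 `COc1ccc(C2C(C3CC3)C(=O)N2c2cc(OC)c(OC)c(OC)c2)cc1`, which gives 120 nM, but beyond the scatter of compound 1. For the measured compounds named here, with only three compounds and no pair differing in a single place, no measured step can be quoted, so any expectation for a new compound rests on the pattern of these values alone.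

Compound 4 `CCSc1ccc(C2C(Oc3ccccc3)C(=O)N2c2cc(OC)c(OC)c(OC)c2)cc1` has not been measured. It differs from compound 2 in this way: phenoxy in place of hydrogen on a saturated ring carbon. Compound 1, which also carries a phenoxy group at the corresponding place of the core, gives 69 nM, the lowest number of the set. On that basis a moderate move toward a lower number is expected for the step of a 1.8-fold lower number from compound 2 to compound 4 (0.25 log units; within the scatter), though its size may well stay close to the scatter. Compound 4 is estimated at 80 nM in this assay, with a likely range from 35 nM to 180 nM.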

Compound 4, half-maximal inhibitory concentration: 210 nM
Compound 4: the middle estimate sits 2.6-fold (0.42 log units) below what was measured; measured number above the stated range.
By their numbers in this assay, from the lowest: compounds 1, 3, 2 and 4 (each within the scatter of the next, the first and the last beyond it).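

In this assay, the saturated ring carbon of the four-membered ring accepts a phenoxy group in place of hydrogen with only a 1.5-fold higher number from compound 2 to compound 4 (0.17 log units; within the scatter), a step within the scatter, so with the 4-(ethylsulfanyl)phenyl group present the phenoxy group brings no clear shift. With phenoxy held constant, ethylsulfanyl in place of ethoxy on an aromatic carbon gives a 3.0-fold higher number from compound 1 to compound 4 (0.48 log units; beyond the scatter), a modest step beyond the scatter, which shows that the low number of compound 1 does not come with the phenoxy group alone. Nothing measured here explains either step.

On these data alone, whether phenoxy in place of hydrogen would give a similar step with ethoxy on the aromatic carbon remains open. So does how an amine, a hydroxyl group or a longer alkyl chain would read at this saturated ring carbon.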